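Bromo in place of 4-cyanophenyl: cytotoxicity on HEL cells

This account rests on a few compounds, and the source may have more. Where it says the series, first, only, none or still open, it means among the compounds named here.

Compound 1 `COc1ccc(-c2cc(C)c3ncc(CSCCc4ccccc4)n3c2)cc1`: 20 ug/mL
Compound 2 `Cc1cc(-c2ccc(C#N)cc2)cn2c(CSCCc3ccccc3)cnc12`: >= 20 ug/mL

In an ADME assay on HEL cells (Homo sapiens) for cytotoxicity, with a stated time of 3 days (on this read-out higher numbers stand for lower toxicity in this test and lower numbers for higher toxicity in this test), compound 1 gives 20 ug/mL. Compound 2 gives >= 20 ug/mL, which is only a limit of the test. Compound 2 thus stands at the limit of >= 20 ug/mL in this assay, at which 1 of the 2 values shown sits. Within the data shown here, the single measured step, a number no lower from compound 1 to compound 2 (the limit leaves the size open), is of unreadable size. Compound 3 `Cc1cc(Br)cn2c(CSCCc3ccccc3)cnc12` differs from compound 2 by bromo in place of 4-cyanophenyl on an aromatic carbon. No measured step covers such a change, so no direction beyond the scatter can be taken from the numbers shown. Compound 3 is therefore expected to give about 20 ug/mL, within a range of 10 ug/mL to 50 ug/mL. The expected step of a number no higher from compound 2 to compound 3 (the limit leaves the size open) is judged to lie within the scatter.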

Compound 3, minimum cytotoxic concentration: >= 2 ug/mL
Compound 3 ended at the assay's limit; the forecaster's own chance of this, stated with the estimate: 60%; the middle value is on the limit's open side.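

In this assay compound 3 gives >= 2 ug/mL, which is only a limit. The steps to it from compound 1 and compound 2 cannot be read. As far as these compounds go, whether bromo in place of 4-cyanophenyl shifts the read-out at all remains open.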